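The source may report more compounds than this note shows. Statements on the series, on what has been measured and on what is new or still open speak of the compounds shown alone.

Working notes on the series. In a functional assay, read by spectrophotometry, with a stated time of 30 min (on this read-out lower numbers stand for an effect already at smaller amounts and higher numbers for an effect only at larger amounts of compound), compound 1 `O=C(/C=C/c1ccc(O)c(O)c1)N1CCN(S(=O)(=O)c2cccc3cnccc23)CC1` gives 9930 nM. Compound 2 `O=C(/C=C/c1ccc(O)c(O)c1)N1CCCN(S(=O)(=O)c2cccc3cnccc23)CC1` gives 10000 nM, so these two numbers lie within the scatter of each other and neither stands apart. The next change leads from compound 1 to compound 3 `O=C(CCc1ccc(O)c(O)c1)N1CCN(S(=O)(=O)c2cccc3cnccc23)CC1`, with 2-(3,4-dihydroxyphenyl)ethyl in place of 2-(3,4-dihydroxyphenyl)ethenyl on a carbonyl carbon. Among the compounds with values here, no measured pair shows a change of this kind, so its size in this assay cannot be read from the data. The working expectation therefore stays anchored on compound 1 at 9930 nM, with no step beyond the scatter in either direction. The expected change is a 1.0-fold higher number from compound 1 to compound 3 (0.00 log units; within the scatter). For compound 3 the estimated value is 10000 nM, with an expected range of 4500 nM to 22000 nM.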

Compound 3, half-maximal effective concentration: 10100 nM
Compound 3: middle estimate off by 1.0-fold (0.00 log units), on the low side, and the stated range covers the measured number.
By their numbers in this assay, from the lowest: compounds 1, 2 and 3 (each within the scatter of the next).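

In this assay, within the data shown here, 2-(3,4-dihydroxyphenyl)ethyl in place of 2-(3,4-dihydroxyphenyl)ethenyl on a carbonyl carbon gives a 1.0-fold higher number from compound 1 to compound 3 (0.01 log units; within the scatter) and is the first readable step. At this place, the double bond outside aromatic rings can therefore be lost with no change beyond the scatter, so the read-out does not separate the two chains on the core of compound 1. No measured evidence on any property of the two chains accompanies this result.

Going by these compounds, whether a longer chain on the carbonyl carbon, or an amine or a carboxylic acid in place of the two ring hydroxyl groups, would move the number beyond the scatter remains open. Also open, on these data alone, is whether the same change on the core of compound 2 would read the same way.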